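A few compounds are considered here, and "the series" means these few. Any claim that something is new, unique, unknown or untested is made for them only; others in the source may bear on it.

Compound 3 `CC(C)(C)c1cc(CNC(=O)Nc2cccc3[nH]ncc23)n(-c2cccc(C(F)(F)F)c2)n1` gives the lowest number of the three compounds measured in an assay on CHO-K1 cells for antagonist activity at transient receptor potential cation channel subfamily V member 1 (Homo sapiens), read by FLIPR and calcium flux, with a stated time of 6 min; a lower number here means a stronger inhibitor, a higher number a weaker inhibitor: it gives 0.3 nM. Compound 2 `CC(C)(C)c1cc(CNC(=O)Nc2cccc3[nH]ncc23)n(-c2cccc(F)c2)n1` gives 1.3 nM in this assay, and compound 1 `O=C(NCc1cc(C(F)(F)F)nn1-c1ccc(C(F)(F)F)cc1)Nc1cccc2[nH]ncc12` gives 3.8 nM. Within the data shown here, the only single-point step among them is a 4.3-fold lower number from compound 2 to compound 3 (0.64 log units; beyond the scatter), which takes compound 3 to the lowest number in the set.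

Compound 4 `CC(C)(C)c1cc(CNC(=O)Nc2cccc3[nH]ncc23)n(-c2ccc(C(F)(F)F)cc2)n1` differs from compound 3 in one place: 4-(trifluoromethyl)phenyl in place of 3-(trifluoromethyl)phenyl on an aromatic nitrogen, so the two share every atom and differ only in where the trifluoromethyl sits on the phenyl ring attached to the ring nitrogen. Among the measured compounds shown here, no measured step exchanges a 3-(trifluoromethyl)phenyl for a 4-(trifluoromethyl)phenyl, so the step from compound 2 to compound 3 bears only indirectly on it, showing that what this phenyl ring carries matters for the number. For the measured compounds named here, compound 1 carries a 4-(trifluoromethyl)phenyl but differs from compound 4 elsewhere as well, so its value gives no step for this change; it only shows that a compound with that group can give a number in the low single digits.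

The expectation for compound 4 is a step of a 3.3-fold higher number from compound 3 to compound 4 (0.52 log units; beyond the scatter) that may just reach beyond the scatter toward a higher number. Compound 4 is therefore estimated at 1 nM, with a range from 0.3 nM to 3.5 nM.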

Compound 4, inhibition constant: 19.6 nM
For compound 4 the middle estimate is 20-fold (1.29 log units) below the measured one; measured number above the stated range.
By their numbers in this assay, from the lowest: compound 3; then compound 2; then compound 1; then compound 4.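

Moving the trifluoromethyl alone, with the same atoms throughout, gives a 65-fold higher number from compound 3 to compound 4 (1.82 log units; beyond the scatter) in this assay, so where this group sits on the phenyl ring attached to the ring nitrogen governs the number strongly, a point the earlier compounds could not show. The trifluoromethyl does not lower the number wherever it stands: 4-(trifluoromethyl)phenyl in place of 3-fluorophenyl gives a 15-fold higher number from compound 2 to compound 4 (1.18 log units; beyond the scatter) and reverses the direction of a 4.3-fold lower number from compound 2 to compound 3 (0.64 log units; beyond the scatter), where 3-(trifluoromethyl)phenyl takes the place of the same 3-fluorophenyl. With 4-(trifluoromethyl)phenyl held constant, tert-butyl in place of trifluoromethyl on the aromatic carbon gives a 5.2-fold higher number from compound 1 to compound 4 (0.71 log units; beyond the scatter), so the tert-butyl does not bring a lower number in this setting, although compound 2 and compound 3 both carry it and give the lowest numbers of the four.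

Nothing in the data given accounts for the size of these steps. From the compounds shown here alone, it remains open whether an unsubstituted phenyl or a pyridyl ring on the aromatic nitrogen would sit nearer compound 3 or compound 4, and whether the exchange of trifluoromethyl for tert-butyl runs the same way when 3-(trifluoromethyl)phenyl is kept.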